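Tosylate Core Paired with a Trifluoromethylphenyl Triazole

The compounds below may be only part of what the source reports. "The series", "measured", "known", "first", "only" and "open" are said of these compounds alone.

Compound 3 `Cc1ccc(-c2cn(C[C@H]3c4c(ccc(OS(=O)(=O)c5ccc(C)cc5)c4C)[C@@H]4CC[C@@]5(C)C[C@]43CC5=O)nn2)cc1` is examined in a functional assay on SW480 cells (Homo sapiens) for cytotoxicity, read by MTT assay, with a stated time of 4 days; a lower number here means a stronger inhibitor, a higher number a weaker inhibitor. In this assay compound 3 gives only a limit, > 20000 nM. Compound 1 `COc1ccc(-c2cn(C[C@H]3c4c(ccc(OS(=O)(=O)c5ccc(C)cc5)c4C)[C@@H]4CC[C@@]5(C)C[C@]43CC5=O)nn2)cc1` likewise gives only a limit in this assay, > 20000 nM. The step of methyl in place of methoxy on an aromatic carbon accordingly reads a step that the two limits leave unreadable from compound 1 to compound 3. Compound 2 `Cc1c(O)ccc2c1[C@H](Cn1cc(-c3ccc(C(F)(F)F)cc3)nn1)[C@@]13CC(=O)[C@@](C)(CC[C@@H]21)C3`, which carries a free hydroxyl on the shared core and a trifluoromethyl on the pendant ring, also gives only a limit in this assay, > 20000 nM. Among the compounds with values here, every value in this set sits at the limit of > 20000 nM in this assay, at which 3 of the 3 values shown sit, so no measured step has a readable size.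

Compound 4 `Cc1ccc(S(=O)(=O)Oc2ccc3c(c2C)[C@H](Cn2cc(-c4ccc(C(F)(F)F)cc4)nn2)[C@@]24CC(=O)[C@@](C)(CC[C@@H]32)C4)cc1` differs from compound 3 by trifluoromethyl in place of methyl on an aromatic carbon, placed on an aromatic carbon of a six-membered aromatic ring of carbon only. Within the data shown here, no measured step bears on this change with a readable size; compound 2, which already carries the trifluoromethylphenyl group, and compound 3 both sit at the limit. Compound 4 is therefore expected to stay at the limit, a step that the limit leaves unreadable from compound 3 to compound 4. Compound 4 is estimated at 30000 nM, between 12000 nM and 100000 nM.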

Compound 4, half-maximal inhibitory concentration: > 20000 nM
Compound 4: only a limit was reported; the forecaster's own chance of this, stated with the estimate: 85%; the middle value does not contradict the limit.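

In this assay compound 4 gives only a limit, > 20000 nM. No step from compound 1, compound 2 or compound 3 to compound 4 can be read, and all four compounds share one limit: the limit of > 20000 nM in this assay, at which 4 of the 4 values shown sit.

The compounds shown leave open whether any change on the shared core or the pendant ring would give a readable value in this assay.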